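The source may hold more compounds than are shown below. What is called first, only, known or untested is meant among the compounds shown, and "the series" means these compounds.

Working notes on the series.

Compound 1 `COc1ccc(F)cc1Nc1cc(NC(=O)Nc2c(Cl)cccc2Cl)ncn1` and compound 2 `COc1ccc(C(F)(F)F)cc1Nc1cc(NC(=O)Nc2c(Cl)cccc2Cl)ncn1` share a core and differ in one aromatic substituent. In a functional assay on NCI-H226 cells (Homo sapiens) for inhibition, read by MTT assay, with a stated time of 48 h, tested at 10 uM (on this read-out lower numbers stand for less inhibition and higher numbers for more inhibition at the one concentration tested (going by the name of the read-out)), compound 1 gives 31.3%, and in this assay compound 2 gives 60.1%. Among the compounds with values here, the one measured step, trifluoromethyl in place of fluoro on an aromatic carbon, is a number 28.8 percentage points higher from compound 1 to compound 2 (beyond the scatter). Within the data shown here, on the two numbers at hand compound 2 stands highest, with compound 1 the only neighbour, lower by that step.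

Compound 3 `COc1ccc(OC)c(Nc2cc(NC(=O)Nc3c(Cl)cccc3Cl)ncn2)c1` has not been measured in this assay. Its change from compound 2 is methoxy in place of trifluoromethyl on an aromatic carbon. Among the measured compounds shown here, the only step that bears on it is the one from compound 1 to compound 2, which was modest and ran upward on going to trifluoromethyl; methoxy is a different group again, so that step gives a direction to remove trifluoromethyl but not a firm size. The expected step in this assay for compound 3 is downward, a number 22.1 percentage points lower from compound 2 to compound 3 (beyond the scatter), with the estimate resting on the value of compound 2, 60.1%, and the gap to compound 1. The estimate for compound 3 in this assay is 38%, in a range from 18% to 62%.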

Compound 3, a percentage reported as inhibition, at one concentration (the size of the read-out at that concentration, not a potency): 81.7%
For compound 3 the middle estimate is 43.7 percentage points below the measured one; measured number above the stated range.
By their numbers in this assay, from the lowest: compound 1; then compound 2; then compound 3.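

At the position meta to a large group and para to a methoxy group, three substituents can now be compared in this assay: methoxy in place of trifluoromethyl gives a number 21.6 percentage points higher from compound 2 to compound 3 (beyond the scatter), and methoxy in place of fluoro gives a number 50.4 percentage points higher from compound 1 to compound 3 (beyond the scatter). The upward step on going to trifluoromethyl therefore did not mark the top of this position, and the order does not follow the size of the group, since methoxy, with fewer heavy atoms than trifluoromethyl, gives the higher number. Nothing at hand accounts for why methoxy stands above both other groups here.

The compounds shown leave open whether the oxygen of methoxy or the group as a whole carries the gain, a question on which a hydroxyl group, an ethoxy group or an amine at the same carbon would bear. All three numbers are also read at a single concentration, so they give an order of inhibition at that concentration and leave the potency of the compounds open.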